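From ethyl to 3-methoxyphenyl: notes on compound 4

This account rests on a few compounds, and the source may have more. Where it says the series, first, only, none or still open, it means among the compounds named here.

- compound 1 `CC(=O)c1ccc(Oc2ccccc2NC(C)=C2C(=O)CC(c3ccccc3)CC2=O)cc1`: 180 nM
- compound 2 `COc1ccc(Oc2ccccc2NC(C)=C2C(=O)CC(c3ccccc3)CC2=O)cc1OC`: 140 nM
- compound 3 `CCOc1ccccc1NC(C)=C1C(=O)CC(c2ccccc2)CC1=O`: 100 nM

All three values come from a functional assay on HMEC-1 cells (Homo sapiens) for antiproliferative activity, read by cell counting, with a stated time of 4 days; a higher number here means a weaker inhibitor, a lower number a stronger inhibitor. Compound 3, at 100 nM, sits in one group with the other two, with no firm order among them: a 1.4-fold lower number from compound 2 to compound 3 (0.15 log units; within the scatter) and a 1.8-fold lower number from compound 1 to compound 3 (0.26 log units; within the scatter).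

Compound 4 `COc1cccc(Oc2ccccc2NC(C)=C2C(=O)CC(c3ccccc3)CC2=O)c1` carries 3-methoxyphenyl in place of ethyl on an oxygen on an aromatic ring. The two steps above bear most directly on this change, since each exchanges ethyl with another ring-bearing group at that oxygen, 3,4-dimethoxyphenyl or 4-acetylphenyl, though in the opposite direction. The step between those two groups is also small: a 1.3-fold lower number from compound 1 to compound 2 (0.11 log units; within the scatter). A step of similar size is therefore expected in this assay, towards a higher number if any, and none beyond the scatter. The estimated step is a 1.5-fold higher number from compound 3 to compound 4 (0.18 log units; within the scatter). For compound 4 the expected value is 150 nM, with an estimated range from 80 nM to 280 nM.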

Compound 4, half-maximal inhibitory concentration: 59 nM
The estimate for compound 4 lay 2.5-fold (0.41 log units) above the measured number; measured number below the stated range.
By their numbers in this assay, from the lowest: compounds 4, 3, 2 and 1 (each within the scatter of the next, the first and the last beyond it).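

In this assay, the larger 3-methoxyphenyl on this oxygen is tolerated in place of ethyl: the result is a 1.7-fold lower number from compound 3 to compound 4 (0.23 log units; within the scatter) and gives no order between the two. Among these compounds, the new information lies among the ring-bearing groups, which the earlier compounds could not separate. Hydrogen in place of methoxy on an aromatic carbon gives a 2.4-fold lower number from compound 2 to compound 4 (0.38 log units; beyond the scatter) and 3-methoxyphenyl in place of 4-acetylphenyl gives a 3.1-fold lower number from compound 1 to compound 4 (0.48 log units; beyond the scatter), so the substitution on this ring changes the number in a modest way. Nothing available gives a reason for these steps.

Still open, as far as these compounds go, is how an unsubstituted phenyl or a longer chain such as butyl would compare on this oxygen. Also open, from the compounds shown here alone, is whether an amine or a carboxylic acid on the ring would keep the number of compound 4.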